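Compound 4: amino in place of trifluoromethoxy

The source may report more compounds than this note shows. Statements on the series, on what has been measured and on what is new or still open speak of the compounds shown alone.

Measured so far in an ADME assay for permeability, using PAMPA, at pH 7.4; on this read-out higher numbers stand for higher permeability and lower numbers for lower permeability:
- compound 1 `CC(=O)c1ccc(NC(=O)Nc2cc(C)nc3ccccc23)cc1` gives 473 10^-6 cm/s
- compound 2 `Cc1cc(NC(=O)Nc2ccccc2N)c2ccccc2n1` gives 300 10^-6 cm/s
- compound 3 `Cc1cc(NC(=O)Nc2ccc(OC(F)(F)F)cc2)c2ccccc2n1` gives 531 10^-6 cm/s

Compound 3 lies within the usual scatter of both other compounds, so these three numbers cannot be ranked. The next compound is compound 4 `Cc1cc(NC(=O)Nc2ccc(N)cc2)c2ccccc2n1`, which has amino in place of trifluoromethoxy on an aromatic carbon, para to a large group (amino in place of trifluoromethoxy on an aromatic carbon).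

For the measured compounds named here, only one measured step swaps a group on that carbon, trifluoromethoxy in place of acetyl. It is small and stays within the scatter (a 1.1-fold higher number from compound 1 to compound 3 (0.05 log units; within the scatter)). That step does not involve amino. Compound 2 also carries an amino group, and its number (300 10^-6 cm/s) is within the scatter of the value for compound 3 (531 10^-6 cm/s). One compound makes no pattern, so only a modest downward move is expected, close to the edge of the scatter (a 1.6-fold lower number from compound 3 to compound 4 (0.21 log units; within the scatter)). Compound 4 is estimated at 330 10^-6 cm/s (expected range 160 10^-6 cm/s to 600 10^-6 cm/s).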

Compound 4, apparent permeability: 530 10^-6 cm/s
Compound 4: the middle estimate sits 1.6-fold (0.21 log units) below what was measured, within the range that was stated.
By their numbers in this assay, from the lowest: compounds 2, 1, 4 and 3 (each within the scatter of the next).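

At this aromatic carbon, para to a large group, trifluoromethoxy with its 5 heavy atoms and amino with its 1 give numbers that cannot be told apart in this assay (a 1.0-fold lower number from compound 3 to compound 4 (0.00 log units; within the scatter)), and the same holds for amino and acetyl (a 1.1-fold higher number from compound 1 to compound 4 (0.05 log units; within the scatter)). The amino group of the 4-aminophenyl in compound 4 and that of the 2-aminophenyl in compound 2 also cannot be separated (a 1.8-fold higher number from compound 2 to compound 4 (0.25 log units; within the scatter)), so no effect of the group on this carbon or of where amino sits can be read from these compounds. No measurement shown here offers an explanation for these results.

On these data alone, it remains open whether a carboxylic acid or a longer chain on this carbon would give a number beyond the scatter of these four compounds. As far as these compounds go, it is equally open whether a change elsewhere on the shared core would do so.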